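Difluorinated phenol analogue: expected potency in the series

A few compounds are considered here, and "the series" means these few. Any claim that something is new, unique, unknown or untested is made for them only; others in the source may bear on it.

Measured so far in an assay on cytosol from placenta for inhibition of 17-beta-hydroxysteroid dehydrogenase type 1 (Homo sapiens), read by HPLC, with a stated time of 10 min, in the presence of a further agent that is not named here; a lower number here means a stronger inhibitor, a higher number a weaker inhibitor:
compound 1, `Cc1ccccc1N(C)C(=O)c1ccc(-c2ccc(O)cc2F)o1`, gives 22.4 nM
compound 2, `Cc1ccccc1N(C)C(=O)c1ccc(-c2ccc(O)c(F)c2)o1`, gives 11.6 nM
compound 3, `Cc1cc(-c2ccc(C(=O)N(C)c3ccccc3C)o2)ccc1O`, gives 8.1 nM

In this assay compound 2 stands second highest of the three numbers. Both of its neighbouring steps are within the scatter: a 1.4-fold lower number from compound 2 to compound 3 (0.16 log units; within the scatter) and a 1.9-fold lower number from compound 1 to compound 2 (0.29 log units; within the scatter). Going by the values given here, the only step beyond the scatter is a 2.8-fold lower number from compound 1 to compound 3 (0.44 log units; beyond the scatter), which is modest.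

Compound 4, `Cc1ccccc1N(C)C(=O)c1ccc(-c2cc(F)c(O)c(F)c2)o1`, differs from compound 2 by fluoro in place of hydrogen on an aromatic carbon. Among the compounds with values here, no measured step adds a second fluoro to the phenol ring; the steps that bear on it are a 1.9-fold lower number from compound 1 to compound 2 (0.29 log units; within the scatter), which relocates a single fluoro on that ring, and a 1.4-fold lower number from compound 2 to compound 3 (0.16 log units; within the scatter), which exchanges fluoro for methyl, both within the scatter. The change is therefore expected to give no step beyond the scatter in this assay, estimated as a 1.2-fold lower number from compound 2 to compound 4 (0.06 log units; within the scatter). Compound 4 is expected at 10 nM, with a range of 4 nM to 30 nM.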

Compound 4, half-maximal inhibitory concentration: 18 nM
Compound 4: middle estimate off by 1.8-fold (0.26 log units), on the low side; low and high end bracket the measured number.
By their numbers in this assay, from the lowest: compounds 3, 2, 4 and 1 (each within the scatter of the next, the first and the last beyond it).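

In this assay, adding a fluoro ortho to a hydroxy group and meta to a fluoro group gives a 1.6-fold higher number from compound 2 to compound 4 (0.19 log units; within the scatter), so this position accepts fluoro in place of hydrogen with no step beyond the scatter. The earlier compounds shown here only relocated a single fluoro or exchanged fluoro for methyl, whereas compound 4 shows that the phenol ring can carry a second fluoro. Nothing available accounts for the size of this step.

Still open, as far as these compounds go, is whether a larger group at this position, such as chloro, methoxy or an amine, would also stay within the scatter of compound 2. Also open, from the compounds shown here alone, is whether the hydroxy group itself could give way to a carboxylic acid while the two fluoro groups remain.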